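The source may report more compounds than this note shows. Statements on the series, on what has been measured and on what is new or still open speak of the compounds shown alone.

Compound 1, `O=S(=O)(Nc1ccc(-c2nc3ccccc3o2)cc1)c1cccc(O)c1`, is the starting point of this comparison. In an ADME assay on HEK293 cells (Homo sapiens) for cytotoxicity, read by resazurin assay, with a stated time of 48 h (on this read-out higher numbers stand for lower toxicity in this test and lower numbers for higher toxicity in this test), compound 1 gives > 100000 nM, which is a limit of the assay rather than a number. Its trifluoromethyl counterpart, compound 3, `O=S(=O)(Nc1ccc(-c2nc3ccccc3o2)cc1)c1cccc(C(F)(F)F)c1`, likewise gives > 100000 nM, again only a limit. For the measured compounds named here, the one step between them, a step that the two limits leave unreadable from compound 1 to compound 3, therefore cannot be sized. Going by the values given here, the third measured compound, compound 2, `O=S(=O)(Nc1ccc2oc(-c3ccccc3)nc2c1)c1ccccc1F`, gives 72000 nM, the only full number among the three. What the measured set shows is mainly (the limit of > 100000 nM in this assay, at which 2 of the 3 values shown sit).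

The new compound, compound 4, `O=S(=O)(Nc1ccc(-c2nc3ccccc3o2)cc1)c1ccc(F)cc1`, differs from compound 1 in one place: 4-fluorophenyl in place of 3-hydroxyphenyl on a sulfonyl sulfur. Among the compounds with values here, no measured step bears directly on this change; the only comparison involving compound 1 is unreadable, and compound 2 carries its fluorine on a different sulfonyl aryl group within a differently substituted core. With compound 1 already sitting at the limit, the step expected from compound 1 to compound 4 is a number no higher from compound 1 to compound 4 (the limit leaves the size open), and compound 4 is estimated at 100000 nM, within 45000 nM to 220000 nM, quite possibly reported only as a limit again.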

Compound 4, half-maximal cytotoxic concentration: > 100000 nM
Compound 4 ended at the assay's limit (the forecaster's own chance of this, stated with the estimate: 55%); the middle value lies on the limit itself.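

For the compounds shown here, compound 4, like compound 1, gives only a limit in this assay, so no step between them can be read: the limit of > 100000 nM in this assay, at which 3 of the 4 values shown sit. Going by these compounds, how far either compound lies beyond that limit, and whether 4-fluorophenyl and 3-hydroxyphenyl differ at all on this read-out, stays open.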